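Methoxy for Chloro on the Shared Core

The compounds below may be only part of what the source reports. "The series", "measured", "known", "first", "only" and "open" are said of these compounds alone.

Compound 3 `N#Cc1c(Nc2ccc(Cl)cc2)sc2ccccc12` gives 45% in a functional assay on HUVEC cells (Homo sapiens), read by fluorescence and microscopy, with a stated time of 6 h, tested at 10 uM (a higher number here means a weaker effect of the compound at the concentration tested, a lower number a stronger effect), the highest of the three numbers: compound 1 `N#Cc1c(Nc2ccc(C(F)(F)F)cc2)sc2ccccc12` gives 24% and compound 2 `N#Cc1c(Nc2ccc([N+](=O)[O-])cc2)sc2ccccc12` gives 8%, and the steps of a number 21 percentage points higher from compound 1 to compound 3 (beyond the scatter) and a number 37 percentage points higher from compound 2 to compound 3 (beyond the scatter) were both beyond the scatter. Compound 4 `COc1ccc(Nc2sc3ccccc3c2C#N)cc1` differs from compound 3 in one place: methoxy in place of chloro on an aromatic carbon. For the measured compounds named here, no measured step involves a methoxy group, so none bears directly on this change; the measured steps show only that exchanging the group at this place moved the number by modest to large amounts. A step of similar size in either direction, or none beyond the scatter, is therefore possible. Compound 4 is expected to give about 50%, between 25% and 80%. The step expected from this change is a number 5 percentage points higher from compound 3 to compound 4 (within the scatter).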

Compound 4, a percentage reported as activity, at one concentration (the size of the read-out at that concentration, not a potency): 57%
The estimate for compound 4 lay 7 percentage points below the measured number, within the range that was stated.
By their numbers in this assay, from the lowest: compound 2; then compound 1; then compound 3; then compound 4.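

With methoxy, the number rises further than with any earlier group at this place, a number 12 percentage points higher from compound 3 to compound 4 (beyond the scatter) and, against the other two groups, a number 33 percentage points higher from compound 1 to compound 4 (beyond the scatter) and a number 49 percentage points higher from compound 2 to compound 4 (beyond the scatter) in this assay. For the compounds shown here, compound 4 is therefore the weakest of the four at the concentration tested, and the spread at this single position is wider than the earlier compounds showed. Nothing available gives a cause for these steps. Going by these compounds, whether an amine or a carboxylic acid at this place would fall inside or outside this spread remains open.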